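The source may report more compounds than this note shows. Statements on the series, on what has been measured and on what is new or still open speak of the compounds shown alone.

Measured compounds in an ADME assay on the whole organism (Mus musculus, strain CD1), read by LC-MS, using cassette dosing, with a stated time of 24 h, at a dose of 0.4 mg/kg by the intravenous route; on this read-out lower numbers stand for lower exposure and higher numbers for higher exposure at the dose given:
compound 1 `Cc1cn(-c2cc(NC(=O)c3ccc(C)c(Nc4nccc(-c5ccccc5)n4)c3)cc(N3CCNCC3)c2)cn1` gives 127 ng.h/mL
compound 2 `Cc1cn(-c2cc(CN3CCN(C)CC3)cc(NC(=O)c3ccc(C)c(Nc4nccc(-c5ccccc5)n4)c3)c2)cn1` gives 187 ng.h/mL

Compound 2 serves as the starting point. Among the measured compounds shown here, its number and that of compound 1 lie within the scatter of each other; the only measured step, a 1.5-fold higher number from compound 1 to compound 2 (0.17 log units; within the scatter), is accordingly read as no change beyond the scatter.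

Compound 3 `Cc1cn(-c2cc(CCS(N)(=O)=O)cc(NC(=O)c3ccc(C)c(Nc4nccc(-c5ccccc5)n4)c3)c2)cn1` is not yet measured in this assay. It differs from compound 2 by sulfamoylmethyl in place of 4-methylpiperazin-1-yl on a saturated chain carbon bound to an aromatic carbon.

For the measured compounds named here, the one measured step concerns a different change, the exchange of piperazin-1-yl for (4-methylpiperazin-1-yl)methyl, and gives no direct guidance on the entry of sulfamoylmethyl; no measured compound carries a sulfamoyl group. What the data do show is that a change at this part of the molecule left this assay within the scatter once. On that basis compound 3 is expected to give a number close to that of compound 2, with the step of a 1.2-fold lower number from compound 2 to compound 3 (0.10 log units; within the scatter) estimated to stay within the scatter. Compound 3 is therefore estimated at 150 ng.h/mL, with a range from 50 ng.h/mL to 450 ng.h/mL.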

Compound 3, area under the concentration-time curve: 63.7 ng.h/mL
Beside the measured number, compound 3's estimate is 2.4-fold (0.37 log units) above it; the range from low to high includes it.
By their numbers in this assay, from the lowest: compounds 3, 1 and 2 (each within the scatter of the next, the first and the last beyond it).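

In this assay, sulfamoylmethyl in place of 4-methylpiperazin-1-yl on a saturated chain carbon bound to an aromatic carbon gives a 2.9-fold lower number from compound 2 to compound 3 (0.47 log units; beyond the scatter) and is the only step shown that lies beyond the scatter, so the group carried at this position can move this read-out, if modestly. The same compound set against the directly ring-bound piperazin-1-yl gives a 2.0-fold lower number from compound 1 to compound 3 (0.30 log units; within the scatter) within the scatter, so the separation holds only against the (4-methylpiperazin-1-yl)methyl compound and not against both compounds carrying a piperazine ring. No supporting measurement bears on what lies behind the step.

The step exchanges two groups at once, so the compounds shown cannot separate the departure of 4-methylpiperazin-1-yl from the arrival of sulfamoylmethyl. A simple dimethylamino group or a carboxylic acid on the same saturated chain carbon, or a longer chain ending in the sulfamoyl group, would show whether the read-out follows the ring, the sulfamoyl group or the length of the chain.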